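The source may report more compounds than this note shows. Statements on the series, on what has been measured and on what is new or still open speak of the compounds shown alone.

Compound 3 `[N-]=[N+]=NC[C@@H]1CN(n2cccc2)C(=O)O1` stands second highest of the three numbers in an assay for inhibition of Amine oxidase [flavin-containing] A (Bos taurus) (on this read-out higher numbers stand for weaker inhibition and lower numbers for stronger inhibition), giving 2500 nM. Its nearest neighbour is compound 1 `[N-]=[N+]=NC[C@H]1CN(n2cccc2)C(=O)O1`, which in this assay gives 200 nM; the step between them is a 13-fold higher number from compound 1 to compound 3 (1.10 log units; beyond the scatter), the pair being the same compound drawn with different configuration at the ring stereocentre (the fact that one of compounds 1 and 3 is drawn with a defined configuration and the other without, at the place where they differ). Furthest from compound 3 is compound 2 `NC[C@H]1CN(n2cccc2)C(=O)O1`, which in this assay gives 53000 nM. Compound 4 `NC[C@@H]1CN(n2cccc2)C(=O)O1` is the unmeasured partner of compound 3: the change from compound 3 to compound 4 is amino in place of azido on a saturated chain carbon bound to a saturated ring carbon. Within the data shown here, the one measured step that bears directly on it is the same replacement on the other drawn configuration, a 270-fold higher number from compound 1 to compound 2 (2.42 log units; beyond the scatter), a large loss. Transferred to compound 3, a large upward step is anticipated, though the size on the weaker configuration may not match exactly. For compound 4 in this assay the expected step is a 120-fold higher number from compound 3 to compound 4 (2.08 log units; beyond the scatter), and the estimated value is 300000 nM with a range of 60000 nM to 1500000 nM.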

Compound 4, inhibition constant: 1200 nM
For compound 4 the middle estimate is 250-fold (2.40 log units) above the measured one; measured number outside the range, below it.
By their numbers in this assay, from the lowest: compound 1; then compound 4; then compound 3; then compound 2.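

In this assay the azidomethyl to aminomethyl change on the configuration of compound 3 gives a 2.1-fold lower number from compound 3 to compound 4 (0.32 log units; beyond the scatter), so the large loss seen on the other configuration does not hold for this position as a whole. The outcome of the change depends on the configuration at the ring stereocentre: the same change on two cores in this assay, a 270-fold higher number (2.42 log units; beyond the scatter) from compound 1 to compound 2 and a 2.1-fold lower number (0.32 log units; beyond the scatter) from compound 3 to compound 4, 550-fold (2.74 log units) apart, beyond the scatter of two such steps. The order of the configurations also reverses with the group, from a 13-fold higher number from compound 1 to compound 3 (1.10 log units; beyond the scatter) for the azides to a 44-fold lower number from compound 2 to compound 4 (1.65 log units; beyond the scatter) for the amines, a gap that goes with configuration alone: the fact that compounds 2 and 4 differ only in the configuration as drawn.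

Going by these compounds, whether this reversal extends to other groups on the saturated chain carbon, such as a hydroxyl, a methylamino or a longer chain ending in an amine, remains open. The values alone also do not say why the two configurations respond in opposite directions.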